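The source may hold more compounds than are shown below. What is called first, only, known or untested is meant among the compounds shown, and "the series" means these compounds.

Measured compounds:
compound 1, `Cc1ccc(S(=O)(=O)Nc2ccc(Cl)cc2)cc1`, 9.02 in a physicochemical assay for acid dissociation
compound 2, `O=S(=O)(Nc1ccc(Cl)cc1)c1ccc(Cl)cc1`, 8.3
compound 3, `Cc1ccc(S(=O)(=O)Nc2ccc(F)cc2)cc1`, 9.2

Compound 1 and compound 2 differ in one place, (chloro in place of methyl on an aromatic carbon). That change gave a number 0.72 log units lower from compound 1 to compound 2 (beyond the scatter), a step beyond the scatter. Compound 3 shares the core of compound 1 apart from one difference, (fluoro in place of chloro on an aromatic carbon), and that difference gave a number 0.18 log units higher from compound 1 to compound 3 (within the scatter), which lies within the scatter, so the two cores are treated as behaving alike in this assay.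

Compound 4, `O=S(=O)(Nc1ccc(F)cc1)c1ccc(Cl)cc1`, is not yet measured. It differs from compound 3 by chloro in place of methyl on an aromatic carbon, the same change that was made from compound 1 to compound 2, at a place described in the same words. Because the earlier change gave a number 0.72 log units lower from compound 1 to compound 2 (beyond the scatter), the step from compound 3 to compound 4 is expected to be of about the same size, namely a number 0.70 log units lower from compound 3 to compound 4 (beyond the scatter). On that basis compound 4 is estimated at 8.5, expected to fall between 8.2 and 8.8.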

Compound 4, acid dissociation constant: 8.41
For compound 4 the middle estimate is 0.09 log units above the measured one, and the stated range covers the measured number.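

In this assay the change of chloro in place of methyl on an aromatic carbon carried over to the second core, with a number 0.79 log units lower from compound 3 to compound 4 (beyond the scatter) alongside a number 0.72 log units lower from compound 1 to compound 2 (beyond the scatter); both steps run in the same direction and both lie beyond the scatter. The fluoro in place of chloro change also stayed within the scatter on the second core, with a number 0.11 log units higher from compound 2 to compound 4 (within the scatter) matching its earlier behaviour. This is a single repeat across two closely related cores, so it supports carrying the change between these two cores only, not to cores outside the series, and no measurement available here accounts for the size of the step.

Only methyl, chloro and fluoro appear on the aromatic rings of the compounds shown, so the size of the step with a nitrile, an amine or a carboxylic acid in the same place remains open. Also open, as far as these compounds go, is whether the chloro in place of methyl step would hold on a core carrying a longer chain.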